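Chloro Position on the Ring-Nitrogen Aryl Group

A few compounds are considered here, and "the series" means these few. Any claim that something is new, unique, unknown or untested is made for them only; others in the source may bear on it.

Working notes on the series. Three compounds have numbers in a functional assay on A549 cells (Homo sapiens) for antiproliferative activity, read by CCK-8 assay, with a stated time of 72 h; on this read-out lower numbers stand for stronger inhibition and higher numbers for weaker inhibition. Compound 1 `CC1=NN(c2ccc(C)cc2)C(=O)C12C=CC(=O)C=C2c1ccc(C)cc1` gives 37000 nM. Compound 2 `CC1=NN(c2cccc(Cl)c2)C(=O)C12C=CC(=O)C=C2c1ccccc1` gives 18800 nM. Compound 3 `CC1=NN(c2ccc(Cl)cc2)C(=O)C12C=CC(=O)C=C2c1ccc(C)cc1` gives 33400 nM. On these numbers compound 3 stands second highest of the three; its nearest neighbour is compound 1 and its furthest is compound 2, and both gaps lie within the scatter, so the three cannot be ordered against each other.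

Among the compounds with values here, the only step with a single structural change is a 1.1-fold lower number from compound 1 to compound 3 (0.04 log units; within the scatter), which lies within the scatter.

Compound 4 `CC1=NN(c2cccc(Cl)c2)C(=O)C12C=CC(=O)C=C2c1ccc(C)cc1` differs from compound 3 by 3-chlorophenyl in place of 4-chlorophenyl on an amide-type nitrogen in a ring. Within the data shown here, no measured step covers exactly this change. Compound 2 carries the 3-chlorophenyl group on the same nitrogen, with an unsubstituted phenyl on the other aryl position, and its number and that of compound 3 lie within the scatter of each other. Together with the single-change step already seen, this gives no reason to expect a step beyond the scatter in this assay in either direction.

Compound 4 is therefore expected to give 28000 nM, with a range from 12000 nM to 65000 nM. The expected step is a 1.2-fold lower number from compound 3 to compound 4 (0.08 log units; within the scatter), within the scatter.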

Compound 4, half-maximal inhibitory concentration: 9050 nM
Compound 4: the middle estimate sits 3.1-fold (0.49 log units) above what was measured; the measured number lies below the stated range.
By their numbers in this assay, from the lowest: compound 4; then compounds 2, 3 and 1 (each within the scatter of the next).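

In this assay, a 3.7-fold lower number from compound 3 to compound 4 (0.57 log units; beyond the scatter) comes from 3-chlorophenyl in place of 4-chlorophenyl on the amide-type nitrogen, so the read-out responds to where the chloro sits on this aryl group even though the groups that leave and enter have the same atoms; the only earlier single-change step, a 1.1-fold lower number from compound 1 to compound 3 (0.04 log units; within the scatter), had shown no such response. Further single-change steps point the same way: a 4.1-fold lower number from compound 1 to compound 4 (0.61 log units; beyond the scatter) follows from 3-chlorophenyl in place of 4-methylphenyl on that nitrogen, and a 2.1-fold lower number from compound 2 to compound 4 (0.32 log units; beyond the scatter) follows from methyl in place of hydrogen on an aromatic carbon with 3-chlorophenyl held constant. No measurement bears on why these changes shift the number.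

As far as these compounds go, it remains open whether the response belongs to the chloro itself or to any group at this ring position, which an amine or a carboxylic acid in place of the chloro on the same aryl group could test. From the compounds shown here alone, it also remains open whether the methyl step seen with 3-chlorophenyl on the nitrogen carries over to other groups on that nitrogen.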